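The source may hold more compounds than are shown below. What is called first, only, known or untested is meant among the compounds shown, and "the series" means these compounds.

Values in a functional assay on A-431 cells (Homo sapiens), read by propidium iodide staining, with a stated time of 24 h (on this read-out lower numbers stand for an effect already at smaller amounts and higher numbers for an effect only at larger amounts of compound), for the measured compounds:
- Compound 1 `FC(F)(F)c1cccc(-c2nnc(-c3cccnc3NCc3ccncc3)[nH]2)c1` gives > 10000 nM as a limit of the assay
- Compound 2 `CS(=O)(=O)c1ccc(-c2nnc(-c3cccnc3NCC3COCCO3)[nH]2)cc1` gives > 10000 nM as a limit of the assay
- Compound 3 `c1cnc(NCc2ccncc2)c(-c2nnc(Nc3ccc4c(c3)OCCO4)o2)c1` gives 18 nM as a measured number

Compound 3 holds the only number among these three, as the other two values are limits. For the measured compounds named here, no two measured compounds differ in one place only, so the series gives no direct size for the next change.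

Compound 4 `c1cncc(CNc2ncccc2-c2nnc(Nc3ccc4c(c3)OCCO4)o2)c1` has the same atoms as compound 3, joined differently. The change is pyridin-3-yl in place of pyridin-4-yl on a saturated chain carbon bound to a nitrogen on an aromatic ring and the rest of the structure stays the same.

With compound 3 at 18 nM as the only anchor, a moderate shift toward higher numbers in this assay is expected. The expected size is a 2.5-fold higher number from compound 3 to compound 4 (0.40 log units; beyond the scatter) on this estimate, and a result within the scatter would not surprise. The estimate for compound 4 is 45 nM as the expected value, within an expected range from 10 nM to 400 nM in this same read-out.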

Compound 4, half-maximal effective concentration: 13 nM
For compound 4 the middle estimate is 3.5-fold (0.54 log units) above the measured one; low and high end bracket the measured number.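

In this assay the series now has its first readable step, a 1.4-fold lower number from compound 3 to compound 4 (0.14 log units; within the scatter), for pyridin-3-yl in place of pyridin-4-yl on a saturated chain carbon bound to a nitrogen on an aromatic ring. This read-out does not separate the two pyridine isomers at this position. For the compounds shown here, compound 3 also no longer stands alone as the only compound with a number.

On these data alone, whether the same holds for a ring without a nitrogen, such as phenyl, or for a saturated amine, such as piperidin-4-yl, stays open. Compounds 1 and 2 differ from compounds 3 and 4 in more than one place, so no step to them can be read, and what separates them remains unassigned: the limit of > 10000 nM in this assay, at which 2 of the 4 values shown sit.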